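Series notes: lactone core, aryl-methyl pair, cytotoxicity read-out

The source may hold more compounds than are shown below. What is called first, only, known or untested is meant among the compounds shown, and "the series" means these compounds.

Four compounds share one saturated lactone core carrying two aryl-methyl arms. Among the compounds with values here, compound 1 `CCCCOc1ccc(C[C@H]2C(=O)OC[C@@H]2Cc2ccccc2)cc1` is the only member with a number: in a functional assay on HeLa cells (Homo sapiens) for cytotoxicity, read by WST assay, with a stated time of 48 h (on this read-out lower numbers stand for an effect already at smaller amounts and higher numbers for an effect only at larger amounts of compound), compound 1 gives 27000 nM. Compound 2 `COc1cc(C[C@H]2C(=O)OC[C@@H]2Cc2ccccc2)cc(OC)c1OC` has no result in this assay, compound 2 standing at "not determined" (no result reported). Compound 3 `O=C1OC[C@H](Cc2cccc(O)c2)[C@H]1Cc1ccc(Cl)c(Cl)c1` likewise stands without a number, compound 3 being recorded as "not determined" (no result reported) in this assay; with compound 2 it makes two entries that give no figure. Within the data shown here, no step between measured compounds can therefore be drawn from these data, and nothing is known of how the dichlorophenyl arm of compound 3 behaves.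

Compound 4 `O=C1OC[C@H](Cc2ccc(F)cc2)[C@H]1Cc1ccc(Cl)c(Cl)c1` is the next member to be measured. It differs from compound 3 by 4-fluorophenyl in place of 3-hydroxyphenyl on a saturated chain carbon bound to a saturated ring carbon. Among the measured compounds shown here, with no measured step anywhere, only the single value of compound 1 anchors the scale, so the step in this assay is expected to be of unknown direction and within or near the scatter. For compound 4 the half-maximal effective concentration is estimated at 20000 nM, expected between 4000 nM and 90000 nM.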

Compound 4, half-maximal effective concentration: 19000 nM
For compound 4 the middle estimate is 1.1-fold (0.02 log units) above the measured one; the range from low to high includes it.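

Within the data shown here, compound 3 stands without a single number in this assay, so no step to compound 4 can be read. The compounds shown leave open how 4-fluorophenyl in place of 3-hydroxyphenyl shifts this read-out. No supporting data bear on the result of compound 4.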